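The compounds below may be only part of what the source reports. "The series", "measured", "known", "first", "only" and "open" are said of these compounds alone.

Measured so far in a physicochemical assay for acid dissociation:
- compound 1 `NS(=O)(=O)c1ccc(SCCCO)c(F)c1` gives 9.64
- compound 2 `NS(=O)(=O)c1ccc(SCCCCO)c(F)c1` gives 9.82

Compound 1 has a single measured neighbour that lies within the scatter of it, the step on the chain being a number 0.18 log units higher from compound 1 to compound 2 (within the scatter). Compound 3 `COC(=O)c1cc(S(N)(=O)=O)ccc1SCCCO` carries methoxycarbonyl in place of fluoro on an aromatic carbon, ortho to a (3-hydroxypropyl)sulfanyl group and meta to a sulfamoyl group (methoxycarbonyl in place of fluoro on an aromatic carbon). Going by the values given here, no measured step touches that carbon, so the chain step bears on it only loosely. In this assay no change beyond the scatter is expected, the estimated step being a number 0.04 log units lower from compound 1 to compound 3 (within the scatter). For compound 3 the expected value is 9.6, with an estimated range from 9.2 to 10.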

Compound 3, acid dissociation constant: 9.3
For compound 3 the middle estimate is 0.30 log units above the measured one, within the range that was stated.
By their numbers in this assay, from the lowest: compound 3; then compounds 1 and 2 (each within the scatter of the next).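

In this assay, going by these compounds alone, the aromatic carbon ortho to a (3-hydroxypropyl)sulfanyl group proves to be a place where a change registers: methoxycarbonyl in place of fluoro gives a number 0.34 log units lower from compound 1 to compound 3 (beyond the scatter), whereas the only earlier step, on the chain, stayed within the scatter. The step is modest, but it places compound 3 apart from the other two compounds. Nothing at hand accounts for this shift.

Going by these compounds, whether an amine or a carboxylic acid on this carbon would move the number the same way remains open. So does whether methoxycarbonyl gives a similar step on the chain of compound 2.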